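The source may report more compounds than this note shows. Statements on the series, on what has been measured and on what is new or still open speak of the compounds shown alone.

Measured values in a functional assay on MDA-MB-468 cells (Homo sapiens) for antiproliferative activity, read by MTT assay, with a stated time of 72 h (a lower number here means a stronger inhibitor, a higher number a weaker inhibitor), are these:
- compound 1 `COc1cc(-c2nccn2CC(C)C)cc(OC)c1OC` gives > 100000 nM as a limit
- compound 2 `COc1cc(-c2nccn2-c2cccc([N+](=O)[O-])c2)cc(OC)c1OC` gives 7200 nM as a number

Compound 1 stands at the limit of > 100000 nM in this assay, at which 1 of the 2 values shown sits, and so offers a limit and no number to start from.

Compound 3 `COc1cc(-c2nccn2-c2ccc(F)cc2)cc(OC)c1OC` has 4-fluorophenyl in place of isobutyl on an aromatic nitrogen of the shared core, counted as 4-fluorophenyl in place of isobutyl on an aromatic nitrogen with the rest of the structure unchanged.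

For the measured compounds named here, no measured pair isolates this change. Going by the values given here, the only numerical guide is compound 2 at 7200 nM with an aromatic ring of its own on that nitrogen.

The expected step of an at least 10-fold lower number from compound 1 to compound 3 (1.00 log units; beyond the scatter) in this assay runs towards stronger inhibition and is estimated to lie beyond the scatter, with its true size open while the starting point is only a limit.

Compound 3 is estimated at 10000 nM with an expected range of 2000 nM to 60000 nM for now.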

Compound 3, half-maximal inhibitory concentration: 62200 nM
Estimate against measurement, compound 3: 6.2-fold (0.79 log units) below, and the stated range ends below it.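

Placing 4-fluorophenyl in place of isobutyl on the aromatic nitrogen gives an at least 1.6-fold lower number from compound 1 to compound 3 (0.20 log units; that floor lies within the scatter) in this assay, and this is the one pair shown that isolates the change. Compound 1 carries a limit and not a number, so the step has only a floor and its true size stays open: the limit of > 100000 nM in this assay, at which 1 of the 3 values shown sits.

Compound 3 gives 62200 nM and compound 2 gives 7200 nM, so an aromatic ring on this nitrogen does not by itself set the value, and what that ring carries goes with the printed difference.

Compound 2 and compound 3 do not separate the identity of the group on that ring from its place on the ring. Going by these compounds, how an amine or a carboxylic acid on that ring, or a longer chain in place of isobutyl, would read in this assay remains open.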